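Replacing the aryl group on the core: toward compound 3

The source may hold more compounds than are shown below. What is called first, only, known or untested is meant among the compounds shown, and "the series" means these compounds.

Measured so far in an assay on CHO cells for antagonist activity at transient receptor potential cation channel subfamily V member 1 (Homo sapiens), read by FLIPR; a higher number here means a weaker inhibitor, a lower number a stronger inhibitor:
- compound 1 `CC(C(=O)NCc1ccc(C(F)(F)F)nc1-c1ccc(C(C)(C)C)cc1)c1ccc(NS(C)(=O)=O)c(F)c1`: 0.5 nM
- compound 2 `CC(C(=O)NCc1ccc(C(F)(F)F)nc1-c1ccoc1)c1ccc(NS(C)(=O)=O)c(F)c1`: 1.4 nM

For the measured compounds named here, compound 1 gives the lowest of the two numbers so far; the nearest is compound 2, and the one step that connects them is a 2.8-fold higher number from compound 1 to compound 2 (0.45 log units; beyond the scatter), a change of furan-3-yl in place of 4-(tert-butyl)phenyl on an aromatic carbon.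

Compound 3 `CC(C(=O)NCc1ccc(C(F)(F)F)nc1/C=C/c1ccccc1)c1ccc(NS(C)(=O)=O)c(F)c1` has not been measured. Against compound 1 it differs as follows: 2-phenylethenyl in place of 4-(tert-butyl)phenyl on an aromatic carbon

Going by the values given here, the only step that bears on this is the one from compound 1 to compound 2, which also removes 4-(tert-butyl)phenyl from the same aromatic carbon and cost a modest amount. A change of comparable character is expected here, so a modest rise in this assay is anticipated rather than none: the expected step is a 2.4-fold higher number from compound 1 to compound 3 (0.38 log units; beyond the scatter). Compound 3 is therefore estimated at 1.2 nM, with a range from 0.4 nM to 4 nM.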

Compound 3, inhibition constant: 2.2 nM
Compound 3: the middle estimate sits 1.8-fold (0.26 log units) below what was measured; low and high end bracket the measured number.
By their numbers in this assay, from the lowest: compound 1; then compounds 2 and 3 (each within the scatter of the next).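

At the aromatic carbon next to the ring nitrogen, a second replacement of 4-(tert-butyl)phenyl also loses potency in this assay, with 2-phenylethenyl giving a 4.4-fold higher number from compound 1 to compound 3 (0.64 log units; beyond the scatter), so the loss is no longer tied to furan-3-yl alone. 2-Phenylethenyl keeps a six-membered aromatic ring of carbon only, yet a 1.6-fold higher number from compound 2 to compound 3 (0.20 log units; within the scatter) places it level with furan-3-yl, and this assay does not separate these two replacements. No measurement is available that explains either step.

The compounds shown leave open how an unsubstituted phenyl or a saturated 2-phenylethyl chain would read at this carbon. Until then, the shares of the tert-butyl group and the double bond in the step from compound 1 cannot be separated.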